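Chloro on the Pendant Phenyl: a Repeated Step

The source may report more compounds than this note shows. Statements on the series, on what has been measured and on what is new or still open speak of the compounds shown alone.

In a functional assay on NCI-H460 cells (Homo sapiens) for cytotoxicity, read by MTT assay, with a stated time of 72 h (a lower number here means a stronger inhibitor, a higher number a weaker inhibitor), compound 1 `COc1cc2c(Oc3ccc(NC(=O)c4cc(-c5cccc(Cl)c5)nc5ccccc45)cc3F)ccnc2cc1OCCCN1CCC(C)CC1` gives 65 nM.
In this assay compound 2 `COc1cc2c(Oc3ccc(NC(=O)c4cc(-c5ccccc5)nc5ccccc45)cc3F)ccnc2cc1OCCCN1CCC(C)CC1` gives 68 nM.
In this assay compound 3 `COc1cc2c(Oc3ccc(NC(=O)c4cc(-c5ccccc5)nc5ccc(F)cc45)cc3F)ccnc2cc1OCCCN1CCCC1` gives 90 nM.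

Compound 1 and compound 2 share one core and differ in a single place: chloro in place of hydrogen on an aromatic carbon. The step that goes with this change is a 1.0-fold lower number from compound 2 to compound 1 (0.02 log units; within the scatter). Compound 3 is built on a different core; how the core of compound 3 differs from that of compound 2 is not broken down here, and the values of compound 2 and compound 3 simply stand close to each other.

Compound 4 `COc1cc2c(Oc3ccc(NC(=O)c4cc(-c5cccc(Cl)c5)nc5ccc(F)cc45)cc3F)ccnc2cc1OCCCN1CCCC1` has not yet been measured. It arises from compound 3 by the same change as that from compound 2 to compound 1: chloro in place of hydrogen on an aromatic carbon. Because that change produced a 1.0-fold lower number from compound 2 to compound 1 (0.02 log units; within the scatter), a step of similar size is expected here, a 1.0-fold lower number from compound 3 to compound 4 (0.01 log units; within the scatter). Since this change is seen only once among the measured compounds, and the core of compound 3 is not the core of compound 1, the expectation is held with a wide range. Compound 4 is estimated at 88 nM, between 45 nM and 175 nM.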

Compound 4, half-maximal inhibitory concentration: 72 nM
Compound 4: the middle estimate sits 1.2-fold (0.09 log units) above what was measured, within the range that was stated.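

In this assay, the change from phenyl to 3-chlorophenyl on the core of compound 3 gives a 1.3-fold lower number from compound 3 to compound 4 (0.10 log units; within the scatter). Set beside the earlier step, the same change reads alike on the two cores: the same change on two cores in this assay, a 1.0-fold lower number (0.02 log units; within the scatter) from compound 2 to compound 1 and a 1.3-fold lower number (0.10 log units; within the scatter) from compound 3 to compound 4, 1.2-fold (0.08 log units) apart, within the scatter of two such steps. This shows that neither pair has a step beyond the scatter, but it rests on two pairs in one cell assay, so it does not show that the same would hold on a further core, nor can it tell a small real effect of the chloro group from the scatter.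

The compounds shown leave open whether a different group on the pendant phenyl, such as methoxy, trifluoromethyl or a nitrile, would give a step beyond the scatter. They also leave open whether the chloro step would stay as small with a morpholine or a carboxylic acid at the end of the side chain.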